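The source may report more compounds than this note shows. Statements on the series, on what has been measured and on what is new or still open speak of the compounds shown alone.

Compound 1, `Cc1cccc2c(=O)cc(/C=C/[S+](C)[O-])oc12`: 6800 nM
Compound 2, `C[S+]([O-])/C=C/c1cc(=O)c2cc(O)ccc2o1`: > 10000 nM

In a functional assay on DLD-1 cells (Homo sapiens) for cytotoxicity, with a stated time of 48 h (on this read-out higher numbers stand for weaker inhibition and lower numbers for stronger inhibition), compound 1 gives 6800 nM. For compound 2 this assay reports only a limit, > 10000 nM, so no number for its potency is known (the limit of > 10000 nM in this assay, at which 1 of the 2 values shown sits). Compound 3, `CC(C)Oc1ccc2oc(/C=C/[S+](C)[O-])cc(=O)c2c1`, differs from compound 2 by one change: isopropyl in place of hydrogen on an oxygen on an aromatic ring. Within the data shown here, no measured pair shows what this change does here, so the step is expected to stay small, within the usual scatter, in no clear direction: an at least 1.1-fold lower number from compound 2 to compound 3 (0.04 log units; that floor lies within the scatter). Compound 3 is therefore estimated at 9000 nM, with a likely range from 3000 nM to 30000 nM.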

Compound 3, half-maximal inhibitory concentration: 8000 nM
Compound 3: middle estimate off by 1.1-fold (0.05 log units), on the high side, within the range that was stated.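

Swapping hydroxy for isopropoxy gives a first reading of a change on this oxygen: in this assay the data show an at least 1.2-fold lower number from compound 2 to compound 3 (0.09 log units; that floor lies within the scatter). With the isopropyl in place, compound 3 gives a measured number, 8000 nM. The true size of the step stays unknown because compound 2 has only a limit: the limit of > 10000 nM in this assay, at which 1 of the 3 values shown sits.

As far as these compounds go, whether an ethyl group, a longer chain or a chain ending in an amine on this same oxygen would give a different number stays open.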